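The source may report more compounds than this note shows. Statements on the series, on what has been measured and on what is new or still open speak of the compounds shown alone.

In a functional assay on HeLa cells (Homo sapiens) for inhibition, read by MTT assay, with a stated time of 48 h (a higher number here means a weaker inhibitor, a lower number a stronger inhibitor), compound 1 (`O=C(CC(c1ccccc1)C(C(=O)Nc1ccccn1)C(=O)Nc1ccccn1)c1ccccc1`) gives 28100 nM while compound 2 (`O=C(CC(c1ccc(F)cc1)C(C(=O)Nc1ccccn1)C(=O)Nc1ccccn1)c1ccccc1`) gives 20800 nM and compound 3 (`O=C(CC(c1ccc([N+](=O)[O-])cc1)C(C(=O)Nc1ccccn1)C(=O)Nc1ccccn1)c1ccccc1`) gives 30000 nM as its half-maximal inhibitory concentration. That places compound 3 level with the other two, inside the usual scatter of both. Compound 4 (`O=C(CC(c1c(Cl)cccc1Cl)C(C(=O)Nc1ccccn1)C(=O)Nc1ccccn1)c1ccccc1`) differs from it (2,6-dichlorophenyl in place of 4-nitrophenyl on a saturated chain carbon bound to two saturated chain carbons) by having 2,6-dichlorophenyl in place of 4-nitrophenyl on a saturated chain carbon bound to two saturated chain carbons. Three measured steps change that aromatic ring: the fluoro swap (a 1.4-fold lower number from compound 1 to compound 2 (0.13 log units; within the scatter)), the nitro swap (a 1.1-fold higher number from compound 1 to compound 3 (0.03 log units; within the scatter)) and the swap of fluoro for nitro (a 1.4-fold higher number from compound 2 to compound 3 (0.16 log units; within the scatter)). All three lie within the scatter. None of these compounds carries chlorine, so this guidance is only indirect, and no step beyond the scatter is expected in this assay here. The estimated change is a 1.3-fold lower number from compound 3 to compound 4 (0.10 log units; within the scatter) and would stay within the scatter. Compound 4 is expected at 24000 nM with an estimated range from 11000 nM to 50000 nM in this measurement.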

Compound 4, half-maximal inhibitory concentration: "not active" (no number reported)
For compound 4 the study gives words and no number, so the estimate cannot be set against anything.
By their numbers in this assay, from the lowest: compounds 2, 1 and 3 (each within the scatter of the next).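

Within the data shown here, compound 4 is reported in this assay only as not active, with no number, so no step from compound 3 to compound 4 can be read. Nothing available explains this result. As far as these compounds go, how 2,6-dichlorophenyl changes the number on the shared core remains open.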